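A few compounds are considered here, and "the series" means these few. Any claim that something is new, unique, unknown or untested is made for them only; others in the source may bear on it.

Going by the values given here, compound 2 `COc1cc2ncnc(Nc3ccc(C)cc3)c2cc1OCCCCC(=O)Nc1ccc(S(N)(=O)=O)cc1` is the only member of this small set with a number in a functional assay on NCI-H1975 cells (Homo sapiens) for antiproliferative activity, read by MTT assay, with a stated time of 72 h; on this read-out higher numbers stand for weaker inhibition and lower numbers for stronger inhibition: in this assay compound 2 gives 19300 nM. Its closest neighbour, compound 1 `COc1cc2ncnc(Nc3ccc(F)cc3)c2cc1OCCCCC(=O)Nc1ccc(S(N)(=O)=O)cc1`, sits at a limit of this assay rather than at a number; in this assay compound 1 gives > 40000 nM, a limit. Among the compounds with values here, the single measured step, an at least 2.0-fold lower number from compound 1 to compound 2 (0.31 log units; beyond the scatter), is the only guide, and the limit side of it is the limit of > 40000 nM in this assay, at which 1 of the 2 values shown sits. Compound 3 `CCc1ccc(Nc2ncnc3cc(OC)c(OCCCCC(=O)Nc4ccc(S(N)(=O)=O)cc4)cc23)cc1` differs from compound 2 by methyl in place of hydrogen on a saturated chain carbon bound to an aromatic carbon. Within the data shown here, no measured pair in this set tests such a chain extension, and the one step available concerns a different exchange, so the expectation is a change of a 1.3-fold lower number from compound 2 to compound 3 (0.11 log units; within the scatter), not clearly beyond the scatter. Compound 3 is therefore estimated at 15000 nM in this assay, with a range from 6000 nM to 40000 nM.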

Compound 3, half-maximal inhibitory concentration: 10300 nM
Compound 3: the middle estimate sits 1.5-fold (0.16 log units) above what was measured; the range from low to high includes it.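

In this assay, going from 4-methylphenyl to 4-ethylphenyl gives a 1.9-fold lower number from compound 2 to compound 3 (0.27 log units; within the scatter), so this added methyl on the saturated chain carbon bound to an aromatic carbon does not clearly separate the two compounds. Ethyl in place of fluoro gives an at least 3.8-fold lower number from compound 1 to compound 3 (0.58 log units; beyond the scatter), so compound 3, like compound 2, stands clearly apart from the fluoro compound. Compound 1 remains at a limit, so the full size of that step cannot be read: the limit of > 40000 nM in this assay, at which 1 of the 3 values shown sits.

The compounds shown leave open whether a longer chain such as propyl, or a branched group such as isopropyl, would move the number beyond the scatter at this place. They also leave open how a methoxy group, an amine or a carboxylic acid would read there.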